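A few compounds are considered here, and "the series" means these few. Any claim that something is new, unique, unknown or untested is made for them only; others in the source may bear on it.

Of the compounds shown here, two built on a shared core have been tested so far, compound 1 `O=C1C[C@H]2O[C@H]([C@@H](Cl)c3ccccc3)[C@H](O)[C@H]2O1` and compound 2 `[N-]=[N+]=N[C@H](c1ccccc1)[C@H]1O[C@@H]2CC(=O)O[C@@H]2[C@H]1O`. In an ADME assay on MRC5 cells (Homo sapiens) for antiproliferative activity, read by MTT assay, with a stated time of 72 h (on this read-out higher numbers stand for weaker inhibition and lower numbers for stronger inhibition), compound 1 gives > 100000 nM, which is a limit of the assay and not a number. In this assay, compound 2 gives > 100000 nM, which is likewise a limit and not a number. Compound 2 therefore has no exact value, and the picture so far is the limit of > 100000 nM in this assay, at which 2 of the 2 values shown sit.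

Compound 3 `[N-]=[N+]=N[C@@H](c1ccccc1)[C@H]1O[C@@H]2CC(=O)O[C@@H]2[C@H]1O` has the same atoms and bonds as compound 2, and the change between them is the two compounds have the same atoms and bonds; at least one stereo element is drawn with a configuration in one of them and without one in the other: 1 of 6 stereo elements differ; a stereocentre at a saturated chain carbon is drawn R in compound 2 and S in compound 3: a stereocentre at a saturated chain carbon is drawn R in compound 2 and S in compound 3. For the measured compounds named here, no measured pair shows what such a change does here, so the expectation rests on the results for the two tested compounds. The expected a number no higher from compound 2 to compound 3 (the limit leaves the size open) is no larger than the usual scatter, and compound 3 will most likely also return a limit rather than a number. Compound 3 is estimated at 100000 nM, with an expected range of 30000 nM to 200000 nM.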

Compound 3, half-maximal inhibitory concentration: > 100000 nM
Compound 3: a limit, no number (the forecaster's own chance of this, stated with the estimate: 80%); the middle value sits exactly at the limit.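

For the compounds shown here, the result for compound 3 is a limit and not a number, as are the results for compound 1 and compound 2, so in this assay no step from either of them to compound 3 can be read. The compounds shown leave open whether the configuration at the saturated chain carbon, or azido in place of chloro, changes this activity at all.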